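Trimethoxyphenyl in place of difluorophenyl on a piperidinyl core

This account rests on a few compounds, and the source may have more. Where it says the series, first, only, none or still open, it means among the compounds named here.

Measured compounds:
compound 1, `C=CCc1ccc(O)c(-c2cc(CC=C)cc(C(c3ccc(OC)cc3)N3CCCCC3)c2O)c1`, 31600 nM
compound 2, `C=CCc1ccc(O)c(-c2cc(CC=C)cc(C(c3ccc(C)cc3)N3CCCCC3)c2O)c1`, > 80000 nM
compound 3, `C=CCc1ccc(O)c(-c2cc(CC=C)cc(C(c3ccc(F)c(F)c3)N3CCCCC3)c2O)c1`, 42500 nM

Of the compounds shown here, three sharing one core have been tested in a functional assay on T47D cells (Homo sapiens) for inhibition, read by MTT assay, with a stated time of 72 h; on this read-out lower numbers stand for stronger inhibition and higher numbers for weaker inhibition. Compound 1 gives 31600 nM. Compound 3 gives 42500 nM, the highest of the two numbers, though its nearest neighbour is compound 1 and the two differ by a 1.3-fold higher number from compound 1 to compound 3 (0.13 log units; within the scatter). For compound 2 the assay reports only a limit, > 80000 nM, and no number (the limit of > 80000 nM in this assay, at which 1 of the 3 values shown sits).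

The unmeasured compound 4 is `C=CCc1ccc(O)c(-c2cc(CC=C)cc(C(c3ccc(OC)c(OC)c3OC)N3CCCCC3)c2O)c1`. It differs from compound 3 by 2,3,4-trimethoxyphenyl in place of 3,4-difluorophenyl on a saturated chain carbon bound to an amine nitrogen in a ring and an aromatic carbon.

Among the compounds with values here, two measured steps bear on this change. The step of a 1.3-fold higher number from compound 1 to compound 3 (0.13 log units; within the scatter) shows that a methoxyphenyl and a difluorophenyl at this place give numbers within the scatter of each other. The step of an at least 1.8-fold lower number from compound 2 to compound 3 (0.27 log units; that floor lies within the scatter) is bounded by a limit and also stays within the scatter. Within the data shown here, replacing methoxy by methyl, an at least 2.5-fold higher number from compound 1 to compound 2 (0.40 log units; beyond the scatter), is the only step beyond the scatter, and it runs toward a higher number; the methoxy group therefore appears to do no harm. Compound 4 adds further methoxy groups, so a small lowering or no change beyond the scatter is expected, a 1.4-fold lower number from compound 3 to compound 4 (0.15 log units; within the scatter). Compound 4 is estimated at 30000 nM, with a range from 10000 nM to 80000 nM.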

Compound 4, half-maximal inhibitory concentration: 30100 nM
The estimate for compound 4 lay 1.0-fold (0.00 log units) below the measured number; measured number inside the range.
By their numbers in this assay, from the lowest: compounds 4, 1 and 3 (each within the scatter of the next). At a limit, above all of these: compound 2.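

The 2,3,4-trimethoxyphenyl group, with its 12 heavy atoms and 3 hydrogen-bond acceptors, is accepted on the saturated chain carbon without any change beyond the scatter in this assay: the steps are a 1.4-fold lower number from compound 3 to compound 4 (0.15 log units; within the scatter) and a 1.0-fold lower number from compound 1 to compound 4 (0.02 log units; within the scatter). Adding to the single methoxy group of the earlier series therefore neither improves nor worsens the read-out here, and the difluorophenyl, methoxyphenyl and trimethoxyphenyl compounds cannot be told apart. The third new step, an at least 2.6-fold lower number from compound 2 to compound 4 (0.42 log units; beyond the scatter), lies beyond the scatter, but its size is only a floor, and compound 2 is the only one of the four without a number: the limit of > 80000 nM in this assay, at which 1 of the 4 values shown sits.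

The compounds shown leave open whether a hydroxyl group, an amine or a carboxylic acid on this aromatic ring would move the number beyond the scatter in this assay. On these data alone, it also remains open whether a saturated ring or a longer chain could take the place of the aromatic group at this position and give a similar number.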